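Replacing the 1-methylpenta-2,4-dien-1-yl group of compound 2

The compounds below may be only part of what the source reports. "The series", "measured", "known", "first", "only" and "open" are said of these compounds alone.

In a functional assay on PC-3 cells (Homo sapiens) for inhibition (on this read-out higher numbers stand for weaker inhibition of growth and lower numbers for stronger inhibition of growth), compound 1 `C=C/C=C\[C@H](C)[C@H](OC(N)=O)[C@@H](C)[C@H](O)CC/C=C\C(C)[C@@H](O)[C@@H](C)/C=C\CC[C@@H]1OC(=O)[C@H](C)[C@@H](OCOC)[C@@H]1C` gives 1.8 nM and compound 2 `C=C/C=C\[C@H](C)[C@H](OC(N)=O)[C@@H](C)[C@H](O)CC/C=C\C(C)[C@@H](O)[C@@H](C)/C=C\CC[C@@H]1O[C@@H](OC)[C@H](C)[C@@H](OCOC)[C@@H]1C` gives 15 nM as the higher of these two numbers, a gap beyond the scatter. Compound 3 `COCOC1=C(C)C(=O)O[C@@H](CC/C=C\[C@H](C)[C@H](O)C(C)/C=C\CC[C@@H](O)[C@H](C)[C@@H](OC(N)=O)C(C)C)[C@H]1C` reads > 50 nM as a limit of the assay and not a number. The move to compound 4 `CCCCCC(C)(C)[C@H](OC(N)=O)[C@@H](C)[C@H](O)CC/C=C\C(C)[C@@H](O)[C@@H](C)/C=C\CC[C@@H]1O[C@@H](OC)[C@H](C)[C@@H](OCOC)[C@@H]1C` is a group of 8 heavy atoms (8 carbon; no ring) in place of a group of 6 heavy atoms (6 carbon; no ring), on a saturated chain carbon bound to an oxygen next to a carbonyl group and a saturated chain carbon on a saturated chain carbon bound to an oxygen next to a carbonyl group and a saturated chain carbon. Within the data shown here, no measured pair isolates this change, so what follows is only an expectation. In this assay the expected move is towards weaker inhibition of growth and beyond the scatter, with an estimated 5.3-fold higher number from compound 2 to compound 4 (0.73 log units; beyond the scatter) as its size. For compound 4 the estimated value is 80 nM within an expected range of 25 nM to 400 nM overall.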

Compound 4, concentration for 50% growth inhibition: 38 nM
The estimate for compound 4 lay 2.1-fold (0.32 log units) above the measured number; low and high end bracket the measured number.
By their numbers in this assay, from the lowest: compound 1; then compound 2; then compound 4. At a limit, above all of these: compound 3.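

In this assay the change at this saturated chain carbon gives a 2.5-fold higher number from compound 2 to compound 4 (0.40 log units; beyond the scatter) and so stays modest. The 2 double bonds of the 1-methylpenta-2,4-dien-1-yl group are therefore not needed for compound 4 to keep a measurable inhibition of growth, though the number does rise. Nothing given here accounts for the size of this step.

The change alters group size and double bonds together, and the compounds shown do not separate the two. As far as these compounds go, whether a hexyl chain or a phenyl ring at this place would hold the number stays open.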